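The compounds below may be only part of what the source reports. "The series", "measured", "known", "first", "only" and "open" are said of these compounds alone.

Measured so far:
- Compound 1, `COc1cc2c(cc1O)CCC(C)(CC(N)=O)O2`, gives 100% in an ADME assay on SH-SY5Y cells (Homo sapiens) for cytotoxicity, read by MTT assay, with a stated time of 24 h, tested at 12.5 uM; on this read-out lower numbers stand for a stronger effect and higher numbers for a weaker effect at the one concentration tested.
- Compound 2, `COc1cc2c(cc1O)CCC(C)(CCNC(=O)C[C@H]1OC(O)[C@H](O)[C@@H](O)[C@@H]1O)O2`, gives 90.6% in this assay.

Compound 2 stands lowest of the two numbers, but its nearest neighbour is compound 1, a value within the scatter, so the two cannot be ordered. Compound 3, `COc1cc2c(cc1O)CCC(C)(CCNC(C)=O)O2`, differs from compound 2 by hydrogen in place of 3,4,5,6-tetrahydroxyoxan-2-yl on a saturated chain carbon bound to a carbonyl carbon. Going by the values given here, no step between two measured compounds is available to anchor this change, so the account rests on the two values alone. From the values of compound 1 and compound 2 in this assay, a step of a number 4.4 percentage points higher from compound 2 to compound 3 (within the scatter) is expected for compound 3, none beyond the scatter. Compound 3 is estimated at 95%, from 80% to 106%.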

Compound 3, a percentage reported as activity, at one concentration (the size of the read-out at that concentration, not a potency): 83.5%
Beside the measured number, compound 3's estimate is 11.5 percentage points above it, within the range that was stated.
By their numbers in this assay, from the lowest: compounds 3, 2 and 1 (each within the scatter of the next, the first and the last beyond it).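

In this assay, hydrogen in place of 3,4,5,6-tetrahydroxyoxan-2-yl on a saturated chain carbon bound to a carbonyl carbon leaves the two compounds within the scatter (a number 7.1 percentage points lower from compound 2 to compound 3 (within the scatter)), so this large ring has no visible effect on the read-out at this position. Acetamidomethyl in place of carbamoyl on a saturated chain carbon bound to a saturated ring carbon gives the first step beyond the scatter, a modest one (a number 16.5 percentage points lower from compound 1 to compound 3 (beyond the scatter)). Nothing available explains this step. As far as these compounds go, whether an amine or a carboxylic acid on that saturated chain carbon would stay within the scatter of compound 3 remains open. So does the outcome for a longer chain in place of acetamidomethyl.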